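From dichlorophenyl to bromophenyl in a growth assay

This account rests on a few compounds, and the source may have more. Where it says the series, first, only, none or still open, it means among the compounds named here.

Measured in a functional assay on MCF7 cells (Homo sapiens) (a higher number here means a weaker inhibitor of growth, a lower number a stronger inhibitor of growth), so far
- compound 1 `O=S(=O)(/C=C/c1ccc(Br)cc1)Cc1ccc(Nc2ncnc3ccccc23)cc1` gives 91000 nM
- compound 2 `O=S(=O)(/C=C/c1ccc(Cl)c(Cl)c1)Cc1ccc(Nc2ncnc3ccc(Br)cc23)cc1` gives 14000 nM

Compound 2 holds the lower of the two numbers in this assay, and its gap to compound 1 lies beyond the usual scatter. These two compounds differ in more than one place, so their values alone do not tie that gap to any single change.

Compound 3 `O=S(=O)(/C=C/c1ccc(Br)cc1)Cc1ccc(Nc2ncnc3ccc(Br)cc23)cc1` has not yet been measured. It carries 4-bromophenyl in place of 3,4-dichlorophenyl on a double-bonded chain carbon bound to a double-bonded chain carbon. Everything else matches compound 2. Among the measured compounds shown here, no measured pair shows this change on its own, so the expectation is a cautious one. Compound 3 shares its 4-bromophenyl with compound 1 (91000 nM) and the remainder with compound 2 (14000 nM). A slight drift toward a higher number is therefore expected, but nothing beyond the scatter, with the estimated step being a 1.3-fold higher number from compound 2 to compound 3 (0.11 log units; within the scatter) in this read-out. In this assay compound 3 is expected at 18000 nM (estimated range 8000 nM to 45000 nM).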

Compound 3, concentration for 50% growth inhibition: 5000 nM
The estimate for compound 3 lay 3.6-fold (0.56 log units) above the measured number; the whole stated range lies above it.
By their numbers in this assay, from the lowest: compound 3; then compound 2; then compound 1.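

In this assay, 4-bromophenyl in place of 3,4-dichlorophenyl on a double-bonded chain carbon bound to a double-bonded chain carbon gives a 2.8-fold lower number from compound 2 to compound 3 (0.45 log units; beyond the scatter), so with the rest of the structure held fixed, this position does respond to the change and favours the 4-bromophenyl group in this read-out. Bromo in place of hydrogen on an aromatic carbon, with the 4-bromophenyl group held fixed, gives an 18-fold lower number from compound 1 to compound 3 (1.26 log units; beyond the scatter), a large step that shows this second site can move the number further than the first. The gap between compound 1 and compound 2, which could not be assigned to any single change, now resolves into two separate steps that run in opposite directions, and nothing shown here bears on what lies behind either one.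

As far as these compounds go, it remains open whether the preference for 4-bromophenyl over 3,4-dichlorophenyl would persist on the core of compound 1, which lacks the aromatic bromo, and whether the two steps simply add. From the compounds shown here alone, it is also open how a 4-chlorophenyl group at the first site, or a methoxy group or an amine in place of that aromatic bromo, would compare with compound 3.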